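Side-chain variation at the amino acid of the glycinamide series

The compounds below may be only part of what the source reports. "The series", "measured", "known", "first", "only" and "open" are said of these compounds alone.

Three compounds sharing one core have numbers in a functional assay on the whole organism (Tail, strain ICR) with Mus musculus as the target, in the tail flick test, with a stated time of 150 min, at a dose of 25 umol/kg by the oral route; a lower number here means a weaker effect, a higher number a stronger effect of the compound at the dose given. Compound 1 `O=C(O)[C@@H]1CCCN1C(=O)CN(c1nc(Cl)nc2[nH]cnc12)C1CC1` gives 7.29% in this assay. Compound 2 `NC(=O)CC[C@H](NC(=O)CN(c1nc(Cl)nc2[nH]cnc12)C1CC1)C(=O)O` gives 11.4% in this assay. Compound 3 `CSCC[C@H](NC(=O)CN(c1nc(Cl)nc2[nH]cnc12)C1CC1)C(=O)O` gives 4.14% in this assay. Within the data shown here, the one step between compounds that differ in a single place, a number 7.3 percentage points lower from compound 2 to compound 3 (within the scatter), is within the scatter. On the numbers shown, compound 3 stands at the low end of the three, but its gaps to compound 1 and to compound 2 are both within the scatter, so the three cannot be separated on these data.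

Compound 4 `O=C(CN(c1nc(Cl)nc2[nH]cnc12)C1CC1)N[C@@H](CO)C(=O)O` is not yet measured in this assay. It differs from compound 3 by hydroxy in place of (methylsulfanyl)methyl on a saturated chain carbon, two bonds along the chain from an amide-type nitrogen and a carbonyl carbon. Among the measured compounds shown here, the only measured step at the amino acid side chain, a number 7.3 percentage points lower from compound 2 to compound 3 (within the scatter), bears on this change; it was within the scatter, and the whole range spanned by compound 1, compound 2 and compound 3 is likewise narrow. No step beyond the scatter is therefore expected in this assay, in either direction. For compound 4 the estimated step is a number 2.9 percentage points higher from compound 3 to compound 4 (within the scatter). Compound 4 is expected to give about 7% in this assay, with a range from 0% to 17%.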

Compound 4, a percentage reported as activity, at one dose (the size of the read-out at that dose, not a potency): 18.8%
Estimate against measurement, compound 4: 11.8 percentage points below; measured number above the stated range.
By their numbers in this assay, from the lowest: compounds 3, 1, 2 and 4 (each within the scatter of the next, the first and the last beyond it).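

In this assay, among these compounds, the amino acid side chain first shows a real effect: hydroxy in place of (methylsulfanyl)methyl on this saturated chain carbon gives a number 14.7 percentage points higher from compound 3 to compound 4 (beyond the scatter), the first step at this position to lie beyond the scatter. The same compound also separates from the ring-containing member, with (1-carboxy-2-hydroxyethyl)amino in place of 2-carboxypyrrolidin-1-yl giving a number 11.5 percentage points higher from compound 1 to compound 4 (beyond the scatter), whereas hydroxy in place of carbamoylmethyl gives a number 7.4 percentage points higher from compound 2 to compound 4 (within the scatter), so compound 4 and compound 2 cannot be separated. No measurement at hand accounts for these steps.

On these data alone, it remains open whether the step from the methylsulfanyl side chain follows from the hydroxy group itself or from the shorter chain, and a longer chain ending in hydroxy, such as 2-hydroxyethyl, would help to separate the two readings. As far as these compounds go, how an amine or a carboxylic acid at the same chain position would read in this assay also remains open.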